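Urea aryl substituent swap in the oxadiazole antiproliferative series

This account rests on a few compounds, and the source may have more. Where it says the series, first, only, none or still open, it means among the compounds named here.

Measured compounds in a functional assay on MDA-MB-231 cells (Homo sapiens) for antiproliferative activity, read by MTT assay, with a stated time of 72 h; a higher number here means a weaker inhibitor, a lower number a stronger inhibitor:
compound 1, `COc1cccc(S(=O)(=O)Nc2cccc(-c3nc(-c4ccc(NC(=O)c5cccnc5)cc4Cl)no3)c2)c1`, gives > 10000 nM, which is a limit of this assay.
compound 2, `O=C(Nc1ccc(Cl)cc1)Nc1cccc(-c2nc(-c3ccc(NC(=O)c4cccnc4)cc3Cl)no2)c1`, gives > 10000 nM, again a limit of this assay.
compound 3, `O=C(Nc1cccc(-c2nc(-c3ccc(NC(=O)c4cccnc4)cc3Cl)no2)c1)Nc1cccc(C(F)(F)F)c1`, gives 1900 nM.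

Within the data shown here, compound 3 thus holds the only number in this assay; the two other values sit at the limit of > 10000 nM in this assay, at which 2 of the 3 values shown sit. The step that the two limits leave unreadable from compound 1 to compound 2 cannot be read, as both compounds are at that limit. Among the measured compounds shown here, the step of an at least 5.2-fold lower number from compound 2 to compound 3 (0.72 log units; beyond the scatter) is the one readable comparison of aryl substituents on the urea, and it shows the 3-(trifluoromethyl)phenyl urea clearing the limit where the 4-chlorophenyl urea did not.

Compound 4, `COc1cccc(NC(=O)Nc2cccc(-c3nc(-c4ccc(NC(=O)c5cccnc5)cc4Cl)no3)c2)c1`, is the next urea in the set. Its change from compound 3 is methoxy in place of trifluoromethyl on an aromatic carbon. For the measured compounds named here, no measured pair isolates a methoxy against a trifluoromethyl on the urea aryl ring; the closest guide is the step from compound 2 to compound 3, where removing the only urea that gave a number returned the value to the limit. The expectation is therefore a step back toward weaker activity, estimated as a 2.6-fold higher number from compound 3 to compound 4 (0.42 log units; beyond the scatter), with a real chance that compound 4 again reports only a limit. The estimated value for compound 4 is 5000 nM, in the range 1500 nM to 20000 nM.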

Compound 4, half-maximal inhibitory concentration: 6700 nM
Compound 4: middle estimate off by 1.3-fold (0.13 log units), on the low side; measured number inside the range.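

Methoxy in place of trifluoromethyl on this aromatic carbon, meta to a large group, gives a 3.5-fold higher number from compound 3 to compound 4 (0.55 log units; beyond the scatter) in this assay, and this is the first change on the urea aryl ring that can be sized between two real numbers rather than bounded by a limit. Compound 3 is also no longer the only urea to give a number, although the comparisons with the other two compounds are floors only: the 3-methoxyphenyl urea against the 4-chlorophenyl urea reads an at least 1.4-fold lower number from compound 2 to compound 4 (0.17 log units; that floor lies within the scatter), and the (3-methoxyphenyl)carbamoyl group against the (3-methoxyphenyl)sulfonyl group reads an at least 1.4-fold lower number from compound 1 to compound 4 (0.17 log units; that floor lies within the scatter). Both of these steps start from a limit rather than a number: the limit of > 10000 nM in this assay, at which 2 of the 4 values shown sit.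

Among the compounds shown, no pair keeps one substituent and changes only its place on the urea aryl ring, so the contributions of placement and substituent identity remain unseparated. Going by these compounds, it also remains open how a nitrile or a carboxylic acid at the same aromatic carbon would compare with the trifluoromethyl of compound 3 and the methoxy of compound 4.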